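Removing One Methyl From Compound 3

This account rests on a few compounds, and the source may have more. Where it says the series, first, only, none or still open, it means among the compounds named here.

Three compounds have been examined in a functional assay on CWR22R cells (Homo sapiens) for antiproliferative activity, read by CCK-8 assay, with a stated time of 6 days; on this read-out higher numbers stand for weaker inhibition and lower numbers for stronger inhibition. For compound 1, `CCN(c1cccc(-c2ccccc2)c1)c1ccc(C#N)c(Cl)c1`, the entry reads "not determined" (no result reported), so it offers no guidance. Compound 2, `CCN(c1cccc(-n2ccnc2)c1)c1ccc(C#N)c(C(F)(F)F)c1`, gives 19000 nM, which is a measured number.

Compound 3, `CCN(c1ccc(C#N)c(Cl)c1)c1cc(-n2ccnc2)ccc1C`, gives > 30000 nM, which is a limit of the assay and not a number.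

The next compound, compound 4, `CCN(c1cccc(-n2ccnc2)c1)c1ccc(C#N)c(Cl)c1`, has hydrogen in place of methyl on an aromatic carbon, para to a 1H-imidazol-1-yl group: hydrogen in place of methyl on an aromatic carbon. Going by the values given here, no measured pair shows what this kind of change does in this assay, so the expectation is tentative. The nearest numerical guide is compound 2 at 19000 nM, which suggests that a number may be obtained. A modest shift toward stronger inhibition is expected, estimated as an at least 1.5-fold lower number from compound 3 to compound 4 (0.19 log units; that floor lies within the scatter), though it may not clearly exceed the usual scatter. For compound 4 the estimated value is 19000 nM, with an expected range from 8000 nM to 30000 nM.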

Compound 4, half-maximal inhibitory concentration: > 30000 nM
Compound 4 was reported as a limit (the forecaster's own chance of this, stated with the estimate: 35%); middle value at least 1.5-fold (0.19 log units) from the limit.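

With hydrogen in place of methyl on this aromatic carbon, para to a 1H-imidazol-1-yl group, compound 4 still gives only a limit of the assay and not a number, so this change does not bring the read-out into the measurable range. The effect of the change itself cannot be read because compound 3 and compound 4 both end at the same limit: the limit of > 30000 nM in this assay, at which 2 of the 4 values shown sit.

Going by these compounds alone, the one readable comparison concerns a different place, chloro in place of trifluoromethyl on an aromatic carbon, and it is an at least 1.5-fold higher number from compound 2 to compound 4 (0.19 log units; that floor lies within the scatter).

The compounds shown carry only methyl or hydrogen on this carbon, so what an amine, a carboxylic acid or a longer chain would do there remains open. Also open, as far as these compounds go, is how far the number for compound 4 actually lies from that of compound 2, since only a floor for that step is known.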